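One chloro group added at the assay limit

The source may hold more compounds than are shown below. What is called first, only, known or untested is meant among the compounds shown, and "the series" means these compounds.

Compound 3 (`Cn1cnc2c(NCc3ccccc3)nc(Nc3ccccc3)nc21`) gives > 10000 nM in an ADME assay on C2C12 cells (Mus musculus) for cytotoxicity (on this read-out lower numbers stand for higher toxicity in this test and higher numbers for lower toxicity in this test), and this is a limit, not a number. Compound 1 (`c1ccc(CNc2nc(Nc3ccccc3)nc3ccccc23)cc1`) gives > 10000 nM and this too is a limit. Compound 2 (`c1ccc(CNc2nc(Nc3nccs3)nc3ccccc23)cc1`) gives > 10000 nM as a limit as well. The data so far therefore show the limit of > 10000 nM in this assay, at which 3 of the 3 values shown sit, and nothing finer.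

Compound 4 (`Cn1cnc2c(NCc3ccccc3)nc(Nc3ccc(Cl)cc3)nc21`) changes compound 3 in one place, where phenyl becomes 4-chlorophenyl: chloro in place of hydrogen on an aromatic carbon and the rest stays the same. Among the measured compounds shown here, the only measured step, a step that the two limits leave unreadable from compound 1 to compound 2 and it concerns a different group, so it gives no size to carry over. Since compound 3 sits at > 10000 nM no step beyond the scatter is expected in either direction, though the data cannot exclude one. The estimated step is a step that the limit leaves unreadable from compound 3 to compound 4 and another reading at the same limit is the likeliest outcome. In this assay the estimate for compound 4 is 15000 nM with an expected range from 5000 nM to 40000 nM if a number is reported.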

Compound 4, half-maximal cytotoxic concentration: > 10000 nM
Compound 4: no number, only a limit; the forecaster's own chance of this, stated with the estimate: 80%; the middle value does not contradict the limit.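

Compound 3 and compound 4 both give only a limit in this assay, so the chloro change yields no readable step: the limit of > 10000 nM in this assay, at which 4 of the 4 values shown sit.

The compounds shown leave open whether adding chloro changes cytotoxicity at all, and at what concentration any of these four compounds would harm the cells.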